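This account rests on a few compounds, and the source may have more. Where it says the series, first, only, none or still open, it means among the compounds named here.

Working notes on the series.

Three compounds of the shared core carry a trimethoxyphenyl-bearing benzyl group and an alkyl chain on the ring nitrogen; they differ only in that chain. Compound 1 `CCCCCCCCN1CC(=O)N(C)[C@@H](Cc2ccc(-c3cc(OC)c(OC)c(OC)c3)cc2)C1=O` gives 400 nM in a functional assay for agonist activity at follicle-stimulating hormone receptor (Homo sapiens), read by a luciferase reporter; a higher number here means that more compound is needed for the effect, a lower number that less compound is needed. Compound 2 `CCCCCCCN1CC(=O)N(C)[C@@H](Cc2ccc(-c3cc(OC)c(OC)c(OC)c3)cc2)C1=O` gives 2300 nM in this assay, and compound 3 `CCCCCN1CC(=O)N(C)[C@@H](Cc2ccc(-c3cc(OC)c(OC)c(OC)c3)cc2)C1=O` gives 9000 nM. Compound 2 therefore stands second highest of the three numbers: a 5.8-fold higher number from compound 1 to compound 2 (0.76 log units; beyond the scatter), while a 3.9-fold higher number from compound 2 to compound 3 (0.59 log units; beyond the scatter) and a 23-fold higher number from compound 1 to compound 3 (1.35 log units; beyond the scatter).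

Compound 4 `CCCCCCCN1C(=O)[C@H](Cc2ccc(-c3cc(OC)c(OC)c(OC)c3)cc2)N(C)C(=O)[C@@H]1C` has not yet been measured. It differs from compound 2 by methyl in place of hydrogen on a saturated ring carbon. Within the data shown here, none of the measured steps touches a ring carbon; all three concern the length of the chain on the ring nitrogen, so they do not bear directly on this change and give no direction for it. With the heptyl chain kept, the expectation is a step of about a 1.1-fold higher number from compound 2 to compound 4 (0.04 log units; within the scatter), not clearly beyond the scatter. For compound 4 the estimate in this assay is 2500 nM, with a range from 700 nM to 9000 nM.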

Compound 4, half-maximal effective concentration: 25 nM
Estimate against measurement, compound 4: 100-fold (2.00 log units) above, outside the stated range (below it).
By their numbers in this assay, from the lowest: compound 4; then compound 1; then compound 2; then compound 3.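

In this assay, methyl in place of hydrogen on a saturated ring carbon, next to the ring atom that bears a heptyl group, gives a 92-fold lower number from compound 2 to compound 4 (1.96 log units; beyond the scatter) and shows that this ring position, untouched by the chain steps, strongly affects the number. The earlier one-carbon change on the chain, a 5.8-fold higher number from compound 1 to compound 2 (0.76 log units; beyond the scatter), is much smaller in size, so the single added carbon counts for far more on this ring carbon than at the end of the chain. Nothing available bears on the reason for this step.

The compounds shown leave open whether an ethyl or hydroxymethyl group on this ring carbon, or a methyl of the opposite configuration, would give a similar number. Going by these compounds, whether the methyl gives a step of like size with the octyl or pentyl chain also stays open.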